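The compounds below may be only part of what the source reports. "The series", "measured", "known", "first", "only" and "open" are said of these compounds alone.

Measured in a physicochemical assay for solubility, with a stated time of 24 h, at pH 6.8; a higher number here means a more soluble compound, a lower number a less soluble compound:
- compound 1 `O=C(NC[C@@H]1[C@H]2CN(C(=O)OCc3cc(Cl)cc(Cl)c3)C[C@@H]12)c1ccc2[nH]c(=O)oc2c1`: < 1 ug/mL
- compound 2 `O=C(NC[C@@H]1[C@H]2CN(C(=O)/C=C/c3cc(Cl)cc(Cl)c3)C[C@@H]12)c1ccc2[nH]c(=O)oc2c1`: < 1 ug/mL
- compound 3 `Cc1ccc(COC(=O)N2C[C@@H]3[C@@H](CNC(=O)c4ccc5[nH]c(=O)oc5c4)[C@@H]3C2)nc1`: 56 ug/mL

Compound 1 stands at the limit of < 1 ug/mL in this assay, at which 2 of the 3 values shown sit, and this is a limit, not a number. Compound 4 `Cc1cc(COC(=O)N2C[C@@H]3[C@@H](CNC(=O)c4ccc5[nH]c(=O)oc5c4)[C@@H]3C2)no1` keeps the core of compound 1 and changes one group: 5-methyl-1,2-oxazol-3-yl in place of 3,5-dichlorophenyl on a saturated chain carbon bound to an oxygen next to a carbonyl group. In words, 5-methyl-1,2-oxazol-3-yl takes the place of 3,5-dichlorophenyl.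

The closest guide is an at least 56-fold higher number from compound 1 to compound 3 (1.74 log units; beyond the scatter), where 5-methylpyridin-2-yl replaces the same 3,5-dichlorophenyl. The next guide, an at least 56-fold higher number from compound 2 to compound 3 (1.74 log units; beyond the scatter), points the same way, whereas a step that the two limits leave unreadable from compound 1 to compound 2 gives no direction. A large rise is therefore expected in this assay, an estimated at least 40-fold higher number from compound 1 to compound 4 (1.60 log units; beyond the scatter). The estimate for compound 4 is 40 ug/mL, with an expected range from 10 ug/mL to 150 ug/mL.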

Compound 4, solubility: 63 ug/mL
Estimate against measurement, compound 4: 1.6-fold (0.20 log units) below; the measured number falls inside the stated range.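

In this assay, an at least 63-fold higher number from compound 1 to compound 4 (1.79 log units; beyond the scatter) and an at least 63-fold higher number from compound 2 to compound 4 (1.79 log units; beyond the scatter) show that the large rise seen with 5-methylpyridin-2-yl is not tied to that six-membered ring, since the five-membered 5-methyl-1,2-oxazol-3-yl gives a rise as well. The two rings cannot be told apart here, with a 1.1-fold higher number from compound 3 to compound 4 (0.05 log units; within the scatter). Compound 1 and compound 2 each give only a limit, not a number: the limit of < 1 ug/mL in this assay, at which 2 of the 4 values shown sit.

Still open, as far as these compounds go, is whether a plain phenyl, with no chlorine and no ring nitrogen or oxygen, would give the same rise. From the compounds shown here alone, it is also open how an amine or a carboxylic acid on this ring would behave.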